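This account rests on a few compounds, and the source may have more. Where it says the series, first, only, none or still open, it means among the compounds named here.

Compound 3 `COC(=O)/C=C/c1cccc(N(Cc2ccc(/C=C/c3cccc(Cl)c3)cc2)C(=O)C2CCCCC2)c1` gives 165 nM in an assay on isolated protein with Bile acid receptor (Homo sapiens) as the target; a lower number here means that less compound is needed, a higher number that more compound is needed for the effect. Among the three compounds measured so far it stands with the highest number: compound 1 `COC(=O)/C=C/c1cccc(N(Cc2ccc(-c3ccc(SC)cc3)cc2)C(=O)C(C)C)c1` gives 51 nM, and compound 2 `COC(=O)/C=C/c1cccc(N(Cc2ccc(-c3ccc(N(C)C)cc3)cc2)C(=O)C(C)C)c1` gives 57 nM, both clearly lower than compound 3. For the measured compounds named here, the only single-point comparison among them is a 1.1-fold higher number from compound 1 to compound 2 (0.05 log units; within the scatter), which concerns a different part of the molecule, the group on the aromatic carbon at the far end.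

Compound 4 `COC(=O)/C=C/c1cccc(N(Cc2ccc(/C=C/c3cccc(Cl)c3)cc2)C(=O)C(C)C)c1` keeps everything of compound 3 except the acyl group on the amide nitrogen: isopropyl in place of cyclohexyl on a carbonyl carbon. In words, the cyclohexylcarbonyl becomes an isopropylcarbonyl. Going by the values given here, no measured pair differs in exactly this way, so no step speaks to it directly. What the numbers do show is that compound 1 and compound 2 both carry the isopropylcarbonyl and both sit at lower numbers than compound 3, though they also carry a different tail, so the comparison is not clean.

The expectation is therefore a modestly lower number for compound 4, with a step of a 1.7-fold lower number from compound 3 to compound 4 (0.22 log units; within the scatter) in this assay. Compound 4 is estimated at 100 nM, with a range from 35 nM to 300 nM.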

Compound 4, half-maximal effective concentration: 164 nM
Beside the measured number, compound 4's estimate is 1.6-fold (0.21 log units) below it; measured number inside the range.
By their numbers in this assay, from the lowest: compounds 1 and 2 (each within the scatter of the next); then compounds 4 and 3 (each within the scatter of the next).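

In this assay, swapping the cyclohexyl on the carbonyl carbon for isopropyl gives a 1.0-fold lower number from compound 3 to compound 4 (0.00 log units; within the scatter) and so the two acyl groups cannot be told apart here, even though the ring is lost and the group shrinks to half its heavy atoms. With the isopropylcarbonyl now held constant, the tail can be read on its own: 2-(3-chlorophenyl)ethenyl in place of 4-(dimethylamino)phenyl gives a 2.9-fold higher number from compound 2 to compound 4 (0.46 log units; beyond the scatter) while the same group in place of 4-(methylsulfanyl)phenyl gives a 3.2-fold higher number from compound 1 to compound 4 (0.51 log units; beyond the scatter) and both steps are modest, so among these compounds the differences trace to the tail and not to the acyl group. Nothing available explains why either change has the effect it does.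

The compounds shown leave open how far this indifference at the acyl position reaches, since both groups here contain only carbon, and an acetyl group or an acyl group carrying an amine or a carboxylic acid could read differently. They also leave open whether cyclohexylcarbonyl and isopropylcarbonyl would still match when paired with the tails of compound 1 and compound 2.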